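This account rests on a few compounds, and the source may have more. Where it says the series, first, only, none or still open, it means among the compounds named here.

In a functional assay on MDA-MB-231 cells (Homo sapiens) for cytotoxicity, read by sulforhodamine B assay, with a stated time of 72 h (on this read-out higher numbers stand for weaker inhibition of growth and lower numbers for stronger inhibition of growth), three compounds have been measured so far:

compound 1 `O=C(Nc1ccccc1O)C1CCc2ccccc2N1C(=O)c1ccccc1`, 4210 nM
compound 2 `O=C(Nc1ccccc1O)C1CCc2ccccc2N1`, 5260 nM
compound 3 `O=C(Nc1cc(C(F)(F)F)cc(C(F)(F)F)c1)C1CCc2ccccc2N1`, 8270 nM

Compound 1 differs from compound 2 by benzoyl in place of hydrogen on a nitrogen on an aromatic ring in a ring, and that change gave a 1.2-fold lower number from compound 2 to compound 1 (0.10 log units; within the scatter). Compound 3 carries a different amide partner on the shared core; the difference between the two cores is not broken down here, and the values of compound 3 and compound 2 sit within the scatter of each other.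

Compound 4 `O=C(Nc1cc(C(F)(F)F)cc(C(F)(F)F)c1)C1CCc2ccccc2N1C(=O)c1ccccc1` has not yet been measured. It differs from compound 3 by benzoyl in place of hydrogen on a nitrogen on an aromatic ring in a ring, the same change that leads from compound 2 to compound 1. For compound 4 an expected step of a 1.2-fold lower number from compound 3 to compound 4 (0.07 log units; within the scatter) rests on that earlier step, a 1.2-fold lower number from compound 2 to compound 1 (0.10 log units; within the scatter). Compound 4 is therefore estimated at 7000 nM, with the likely range running from 3000 nM to 16000 nM.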

Compound 4, concentration for 50% growth inhibition: 2430 nM
Compound 4: middle estimate off by 2.9-fold (0.46 log units), on the high side, and the stated range ends above it.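

Benzoyl in place of hydrogen on a nitrogen on an aromatic ring in a ring gave a 3.4-fold lower number from compound 3 to compound 4 (0.53 log units; beyond the scatter) in this assay and so did not carry over at one size from one amide partner to the other: the same change on two cores in this assay, a 1.2-fold lower number (0.10 log units; within the scatter) from compound 2 to compound 1 and a 3.4-fold lower number (0.53 log units; beyond the scatter) from compound 3 to compound 4, 2.7-fold (0.44 log units) apart, beyond the scatter of two such steps. The step measured on the core of compound 2 was thus a poor guide to its size on the core of compound 3. Two cores show that the size of the step depends on the core, but not what sets it or how it would turn out on a third amide partner.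

The compounds shown leave open whether an acetyl group on the same nitrogen would behave as benzoyl does. They also leave open what an amine or a carboxylic acid on the benzoyl ring would do.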